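The compounds below may be only part of what the source reports. "The series", "measured", "known", "first", "only" and "open" are said of these compounds alone.

Compound 1 `CCOc1ccc2nc(C(F)(F)F)cc(OCC(=O)Nc3cc(C)cc(C)c3)c2c1`: in a toxicity assay on HepG2 cells (Homo sapiens) for inhibition, read by CellTiter-Glo, with a stated time of 48 h (a higher number here means a weaker inhibitor, a lower number a stronger inhibitor), compound 1 gives only a limit, > 100000 nM.
Compound 2 `COc1ccc2nc(C)cc(OC(C)(C)C(=O)Nc3cc(C)cc(C)c3)c2c1`: compound 2 likewise gives only a limit, > 100000 nM.
Compound 3 `COc1ccc2nc(C)cc(OCC(=O)NCc3cc(C)cc(C)c3)c2c1`: compound 3 too gives only a limit, > 100000 nM.

Compound 3 therefore stands nowhere in particular among the values shown: none of them is a number, and all three rest at the same limit, as noted in the limit of > 100000 nM in this assay, at which 3 of the 3 values shown sit. Among the compounds with values here, no step between measured compounds can be drawn. Compound 4 `COc1ccc2nc(C)cc(OCC(=O)Nc3noc(C)c3C)c2c1` differs from compound 3 in one place: 4,5-dimethyl-1,2-oxazol-3-yl in place of 3,5-dimethylbenzyl on an amide-type nitrogen. With every measured value sitting at a limit, the step from compound 3 to compound 4 is expected to be none beyond the scatter, a number no higher from compound 3 to compound 4 (the limit leaves the size open). Compound 4 is accordingly expected to give about 100000 nM in this assay, within 40000 nM to 300000 nM, most likely again as a limit rather than a number.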

Compound 4, half-maximal inhibitory concentration: > 100000 nM
Compound 4 gave a limit, no number; the forecaster's own chance of this, stated with the estimate: 85%; the middle value sits exactly at the limit.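

Within the data shown here, compound 3 and compound 4 each give only a limit, and no step between them can be read. The compounds shown leave open whether any of them would reach a number in this assay and how the two groups on the amide-type nitrogen compare.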